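Ortho substituent swap on the aryl urea of compound 2

The compounds below may be only part of what the source reports. "The series", "measured", "known", "first", "only" and "open" are said of these compounds alone.

Compound 2 `COc1cc2ncnc(NCc3cccc(NC(=O)Nc4ccccc4C)c3)c2cc1OC` gives 21400 nM in a functional assay on A549 cells (Homo sapiens) for antiproliferative activity, read by MTT assay; on this read-out lower numbers stand for stronger inhibition and higher numbers for weaker inhibition. Compound 1 `O=C(Nc1ccc(F)cc1)Nc1cccc(CNc2ncnc3ccccc23)c1` gives 21000 nM in this assay, and the two values lie within the usual scatter, so no order between them is read. Compound 3 `COc1cc2ncnc(NCc3cccc(NC(=O)Nc4ccccc4Cl)c3)c2cc1OC` is not yet measured; it differs from compound 2 by chloro in place of methyl on an aromatic carbon. Among the measured compounds shown here, with no step between measured compounds to lean on, the expected change is small, no further than the scatter in either direction. The expected step is a 1.1-fold lower number from compound 2 to compound 3 (0.03 log units; within the scatter), within the scatter. Compound 3 is estimated at 20000 nM, with a range from 8000 nM to 50000 nM.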

Compound 3, half-maximal inhibitory concentration: 15200 nM
The estimate for compound 3 lay 1.3-fold (0.12 log units) above the measured number; low and high end bracket the measured number.
By their numbers in this assay, from the lowest: compounds 3, 1 and 2 (each within the scatter of the next).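

In this assay, chloro in place of methyl on an aromatic carbon ortho to a large group gives a 1.4-fold lower number from compound 2 to compound 3 (0.15 log units; within the scatter), so no order is read between the two. This single one-place step shows that the position accepts either group without a change beyond the scatter. No supporting data bear on this result.

Open, from the compounds shown here alone, is whether a methoxy, trifluoromethyl or amine group at this position would move the number beyond the scatter. Also open, going by these compounds, is whether chloro on another carbon of this ring would do so.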